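One methyl step, two cores: notes toward compound 4

The source may hold more compounds than are shown below. What is called first, only, known or untested is meant among the compounds shown, and "the series" means these compounds.

Measured so far in a functional assay on XF498 cells (Homo sapiens) for inhibition, with a stated time of 72 h; a higher number here means a weaker inhibitor, a lower number a stronger inhibitor:
compound 1 `CC1(c2ccccc2)CC(=O)C(C(CC(=O)c2ccc(-c3ccc(Br)cc3)cc2)c2ccccc2)=C(O)O1` gives 6730 nM
compound 2 `CCC1(c2ccccc2)CC(=O)C(C(CC(=O)c2ccc(-c3ccc(Br)cc3)cc2)c2ccccc2)=C(O)O1` gives 6590 nM
compound 3 `CC1(c2ccccc2)CC(=O)C(C2CC(c3ccc(-c4ccc(Br)cc4)cc3)Cc3ccccc32)=C(O)O1` gives 1360 nM

Compound 1 and compound 2 share one core and differ only by methyl in place of hydrogen on a saturated chain carbon bound to a saturated ring carbon. That change produced a 1.0-fold lower number from compound 1 to compound 2 (0.01 log units; within the scatter). Compound 3 sits on a second core; the difference between the two cores is not broken down here. Its value is the lowest of the three, and its gaps to compound 1 and compound 2 are beyond the scatter, so compound 3 is the strongest inhibitor among the measured set.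

Compound 4 `CCC1(c2ccccc2)CC(=O)C(C2CC(c3ccc(-c4ccc(Br)cc4)cc3)Cc3ccccc32)=C(O)O1` is not yet measured and applies the same change to the core of compound 3: methyl in place of hydrogen on a saturated chain carbon bound to a saturated ring carbon. Because the earlier instance gave a 1.0-fold lower number from compound 1 to compound 2 (0.01 log units; within the scatter), the step for compound 4 is expected to be a 1.0-fold lower number from compound 3 to compound 4 (0.00 log units; within the scatter). On that basis compound 4 is estimated at 1350 nM in this assay, with an expected range from 650 nM to 2800 nM.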

Compound 4, half-maximal inhibitory concentration: > 10000 nM
Compound 4 gave a limit, no number; the forecaster's own chance of this, stated with the estimate: 0%; middle value at least 7.4-fold (0.86 log units) from the limit.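

In this assay, the change of methyl in place of hydrogen does not carry over from one core to the other: the same change on two cores in this assay, a 1.0-fold lower number (0.01 log units; within the scatter) from compound 1 to compound 2 and an at least 7.3-fold higher number (0.86 log units; beyond the scatter) from compound 3 to compound 4, at least 7.5-fold (0.87 log units) apart, beyond the scatter of two such steps

Compound 4 gives > 10000 nM, which is a limit of the assay and not a number.

The step therefore reads as an at least 7.3-fold higher number from compound 3 to compound 4 (0.86 log units; beyond the scatter), and its full size stays unknown; with one pair on each core, this shows that the outcome of the change depends on the core, but not which feature of the core is responsible or why.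

Still open, on these data alone, is how a propyl chain in place of that methyl would behave on each core. Also open, as far as these compounds go, is whether a carboxylic acid there would separate the two cores in the same way.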